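Swapping Chloro for Methoxy at a Second Ring Position

The source may hold more compounds than are shown below. What is called first, only, known or untested is meant among the compounds shown, and "the series" means these compounds.

Four compounds share one core and differ only in the ring attached to a nitrogen. Compound 1 `C#CCSc1nc(Nc2ccccc2Cl)c2ccncc2n1` and compound 2 `C#CCSc1nc(Nc2cccc(Cl)c2)c2ccncc2n1` differ by 3-chlorophenyl in place of 2-chlorophenyl on a nitrogen on an aromatic ring. In a functional assay on HepG2 cells (Homo sapiens) for inhibition, read by MTT assay, with a stated time of 72 h (on this read-out lower numbers stand for stronger inhibition and higher numbers for weaker inhibition), compound 1 gives 17200 nM, while compound 2 gives 1090 nM, which is a 16-fold lower number from compound 1 to compound 2 (1.20 log units; beyond the scatter). Compound 3 `C#CCSc1nc(Nc2ccccc2OC)c2ccncc2n1` arises from compound 1 by methoxy in place of chloro on an aromatic carbon; in this assay compound 3 gives 4530 nM, a step of a 3.8-fold lower number from compound 1 to compound 3 (0.58 log units; beyond the scatter). Compound 4 `C#CCSc1nc(Nc2cccc(OC)c2)c2ccncc2n1` is not yet measured; it arises from compound 2 by methoxy in place of chloro on an aromatic carbon, the same kind of change, though here the place is meta to a large group rather than ortho to it. The step is expected to be a 2.7-fold lower number from compound 2 to compound 4 (0.44 log units; beyond the scatter), resting on a 3.8-fold lower number from compound 1 to compound 3 (0.58 log units; beyond the scatter), with the differing place widening the doubt. Compound 4 is therefore estimated at 400 nM, likely between 120 nM and 1500 nM.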

Compound 4, half-maximal inhibitory concentration: 920 nM
Estimate against measurement, compound 4: 2.3-fold (0.36 log units) below; the range from low to high includes it.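

Putting methoxy in place of chloro gives a 1.2-fold lower number from compound 2 to compound 4 (0.07 log units; within the scatter) in this assay, so on this core the swap leaves the two compounds indistinguishable. Within the data shown here, this rests on only two pairs in a single assay, and it does not show why the results part, or what the change would do on any further core. Still, the same change does not bring a fixed step from one core to the other in this series, as the two steps differ: the same change on two cores in this assay, a 3.8-fold lower number (0.58 log units; beyond the scatter) from compound 1 to compound 3 and a 1.2-fold lower number (0.07 log units; within the scatter) from compound 2 to compound 4, 3.2-fold (0.51 log units) apart, beyond the scatter of two such steps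

The compounds shown leave open what other groups at this place would do, such as a methyl group, a trifluoromethyl group or an amine. They also leave open whether a longer chain in place of the methoxy would follow either step.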